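This account rests on a few compounds, and the source may have more. Where it says the series, first, only, none or still open, it means among the compounds named here.

The measured compounds:
Compound 1, `CCC1=C(O)c2c(oc(-c3ccc(OC)cc3)cc2=O)C(CC)(CC)C1=O`, gives 17.7 uM in a functional assay on KB cells (Homo sapiens) for antiproliferative activity, read by sulforhodamine B assay, with a stated time of 3 days; a higher number here means that more compound is needed for the effect, a lower number that less compound is needed.
Compound 2, `CCC1=C(O)c2c(oc(-c3ccc(F)cc3)cc2=O)C(CC)(CC)C1=O`, gives 33 uM.
Compound 3, `CCC1=C(O)c2c(oc(-c3ccc(OC)c(OC)c3)cc2=O)C(CC)(CC)C1=O`, gives 14.7 uM.

Compound 4 is `CCC1=C(O)c2c(oc(-c3ccc(OC)c(F)c3)cc2=O)C(CC)(CC)C1=O`; its result in this assay is not yet known. Compound 3 differs from compound 1 by methoxy in place of hydrogen on an aromatic carbon, and that difference reads as a 1.2-fold lower number from compound 1 to compound 3 (0.08 log units; within the scatter). Compound 3 has the lowest of the three numbers, but only its gap to compound 2 lies beyond the scatter. The change that leads from compound 3 to compound 4 is fluoro in place of methoxy on an aromatic carbon. The same change appears once before among these compounds, from compound 1 to compound 2, as fluoro in place of methoxy on an aromatic carbon, where it made a 1.9-fold higher number from compound 1 to compound 2 (0.27 log units; within the scatter). It is the same kind of change rather than the same: in compound 1 the group sits para to a large group, whereas in compound 3 it sits ortho to a methoxy group and meta to a large group. The step from compound 3 to compound 4 is expected to be a 1.5-fold higher number from compound 3 to compound 4 (0.18 log units; within the scatter), because the earlier step gave a 1.9-fold higher number from compound 1 to compound 2 (0.27 log units; within the scatter). Compound 4 is accordingly estimated at 22 uM, within a range from 10 uM to 45 uM.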

Compound 4, concentration for half-maximal effect: 26.7 uM
For compound 4 the middle estimate is 1.2-fold (0.08 log units) below the measured one; low and high end bracket the measured number.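

In this assay, fluoro in place of methoxy on an aromatic carbon gave a 1.8-fold higher number from compound 3 to compound 4 (0.26 log units; within the scatter), and the step read almost the same on the core of compound 1 as on the core of compound 3, although the group sits in a different place in each: the same change on two cores in this assay, a 1.9-fold higher number (0.27 log units; within the scatter) from compound 1 to compound 2 and a 1.8-fold higher number (0.26 log units; within the scatter) from compound 3 to compound 4, 1.0-fold (0.01 log units) apart, within the scatter of two such steps
This agreement shows that the change carried across these two cores without a detectable difference, but both steps lie within the scatter, so it does not show that the change itself moves the number, and two pairs set no rule for other cores. The other new steps, a 1.2-fold lower number from compound 2 to compound 4 (0.09 log units; within the scatter) and a 1.5-fold higher number from compound 1 to compound 4 (0.18 log units; within the scatter), also stay within the scatter and add no separate trend.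

The compounds shown leave open how an amine or a carboxylic acid on this aromatic ring would read in this assay. They also leave open whether fluoro in place of methoxy would read the same on a core carrying a longer chain.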